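Swapping the amine-bearing ring on the amide of compound 1

The compounds below may be only part of what the source reports. "The series", "measured", "known", "first", "only" and "open" are said of these compounds alone.

Going by the values given here, compound 1 `N[C@@H]1CCCN(C(=O)c2ccc(-c3ccc4ncc(-c5ccc6cnccc6c5)n4c3)cc2)C1` is one of three compounds measured in an assay on Sf21 cells for inhibition of MAP kinase-interacting serine/threonine-protein kinase 1 (Homo sapiens), read by luminescence and ADP-Glo, with stated times of 10 min and 40 min; a higher number here means a weaker inhibitor, a lower number a stronger inhibitor. In this assay compound 1 gives 7.7 nM, the lowest of the three numbers. Compound 3 `NC1CCN(C(=O)c2ccc(-c3ccc4ncc(-c5ccc6cnccc6c5)n4n3)cc2)CC1` gives 14.5 nM, which stays within the scatter of repeated measurement, so the two cannot be ordered. Compound 2 `O=C(c1ccc(-c2ccc3ncc(-c4cnc5ccccc5c4)n3c2)cc1)N1CCOCC1` gives 154 nM, a clearly weaker result than either.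

Compound 4 `O=C(c1ccc(-c2ccc3ncc(-c4ccc5cnccc5c4)n3c2)cc1)N1CCC(N2CCCCC2)CC1` is not yet measured. It differs from compound 1 in one place: 4-(piperidin-1-yl)piperidin-1-yl in place of 3-aminopiperidin-1-yl on a carbonyl carbon. Compound 3 shows that an amine-bearing piperidine of a different shape still gives a low number, while compound 2 shows that a ring without an amine gives a much higher one; compound 4 keeps an amine within its ring. The step expected from compound 1 to compound 4 in this assay is a 1.9-fold higher number from compound 1 to compound 4 (0.29 log units; within the scatter), a mild weakening that may well fall inside the scatter. Compound 4 is therefore expected to give about 15 nM, with a range from 5 nM to 50 nM.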

Compound 4, half-maximal inhibitory concentration: 2.4 nM
Estimate against measurement, compound 4: 6.3-fold (0.80 log units) above; the measured number lies below the stated range.
By their numbers in this assay, from the lowest: compound 4; then compounds 1 and 3 (each within the scatter of the next); then compound 2.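

At this position on the carbonyl carbon, replacing 3-aminopiperidin-1-yl with the larger 4-(piperidin-1-yl)piperidin-1-yl gives a 3.2-fold lower number from compound 1 to compound 4 (0.51 log units; beyond the scatter) in this assay. The entering group has two rings instead of one and more heavy atoms, and it has no hydrogen-bond donor and no defined stereocentre, so neither of those two features of compound 1 is required for a low number in this pair. The size of the group, the loss of the donor and the loss of the stereocentre all change in this single step, and nothing available shows which of them matters or why the number falls.

From the compounds shown here alone, it remains open whether a smaller group on the same piperidine, such as a dimethylamino group, would give a similar number, or whether the second ring is needed. A morpholine or a piperazine ring in place of the outer piperidine would test how much that ring's nitrogen and remaining atoms contribute.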